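The source may report more compounds than this note shows. Statements on the series, on what has been measured and on what is new or still open speak of the compounds shown alone.

Measured in an ADME assay on Raji cells (Homo sapiens) for cytotoxicity, read by CellTiter-Glo, with a stated time of 72 h; a lower number here means that less compound is needed, a higher number that more compound is needed for the effect:
- compound 1 `CC1=C2CC(C)(C)/C=C/C/C(C)=C\C3=C[C@H](C)C[C@]3(O2)C1=O`: 26000 nM
- compound 2 `C/C1=C/C2=C[C@H](C)C[C@@]23O[C@]2(CC(C)(C)C[C@@H]2[C@@]1(O)C(F)(F)F)[C@@H](C)C3=O`: 26000 nM

Compound 2 stands level with compound 1, within the scatter. Compound 3 `C/C1=C/C2=C[C@H](C)C[C@@]23O[C@]2(CC(C)(C)C[C@@H]2[C@@]1(O)C#N)[C@@H](C)C3=O` differs from compound 2 at one place: cyano in place of trifluoromethyl on a saturated ring carbon. This puts cyano in place of trifluoromethyl on a saturated ring carbon. Going by the values given here, no measured step sizes this change, so in this assay no step beyond the scatter is expected, and no direction is favoured. The estimated change is a 1.2-fold lower number from compound 2 to compound 3 (0.07 log units; within the scatter). For compound 3 the expected value is 22000 nM, with an estimated range of 7000 nM to 50000 nM.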

Compound 3, half-maximal effective concentration: 26000 nM
Beside the measured number, compound 3's estimate is 1.2-fold (0.07 log units) below it; the measured number falls inside the stated range.
By their numbers in this assay, from the lowest: compounds 1, 2 and 3 (each within the scatter of the next).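

In this assay, the position on the saturated ring carbon now has its first sized step: cyano in place of trifluoromethyl gives no change at the digits printed from compound 2 to compound 3 (within the scatter) and stays within the scatter. The hydrogen-bond acceptor on cyano, absent from trifluoromethyl, therefore comes with no readable shift in this read-out. No measured evidence here bears on the reason for this flat result.

Trifluoromethyl and cyano both lack a hydrogen-bond donor and a net charge, so the response to an amine, a carboxylic acid or a longer chain at this carbon remains open. As far as these compounds go, whether any group here can move the number beyond the scatter also remains open.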